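Benzylidene aryl swap in a thioether enone series

A few compounds are considered here, and "the series" means these few. Any claim that something is new, unique, unknown or untested is made for them only; others in the source may bear on it.

Compound 1 `Cc1ccc(CS/C(=C/c2ccc(N(C)C)cc2)C(=O)c2ccc(Cl)cc2)cc1` gives only a limit in a functional assay on DU-145 cells (Homo sapiens) for inhibition, read by trypan blue exclusion, with a stated time of 96 h (on this read-out higher numbers stand for weaker inhibition of growth and lower numbers for stronger inhibition of growth), namely > 100000 nM, which is the limit of > 100000 nM in this assay, at which 1 of the 3 values shown sits. Compound 2 `COc1ccccc1/C=C(/SCc1ccc(C)cc1)C(=O)c1ccc(Cl)cc1` in this assay gives 10000 nM. Compound 3 `COc1ccccc1/C=C(/SCc1ccc(Cl)c(Cl)c1)C(=O)c1ccc(Cl)cc1` in this assay gives 10000 nM. Going by the values given here, the step of an at least 10-fold lower number from compound 1 to compound 2 (1.00 log units; beyond the scatter) is the only measured change at the double-bonded chain carbon bound to a double-bonded chain carbon. The step of no change at the digits printed from compound 2 to compound 3 (within the scatter) concerns the saturated chain carbon bound to a sulfur and is flat, so on the numbers shown compound 2 stands level with compound 3.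

Compound 4 `Cc1ccc(CS/C(=C/c2cc(Cl)cc(Cl)c2)C(=O)c2ccc(Cl)cc2)cc1` is not yet measured. Its change from compound 2 is 3,5-dichlorophenyl in place of 2-methoxyphenyl on a double-bonded chain carbon bound to a double-bonded chain carbon. Among the compounds with values here, the one step that bears on it, an at least 10-fold lower number from compound 1 to compound 2 (1.00 log units; beyond the scatter), shows that the group at this place can shift the read-out considerably, but it compares two other groups and gives no direction for 3,5-dichlorophenyl against 2-methoxyphenyl. The step of no change at the digits printed from compound 2 to compound 3 (within the scatter) does not touch this place and adds nothing on direction. For this assay the expected step is therefore small, no change at the digits printed from compound 2 to compound 4 (within the scatter), with wide uncertainty either way. Compound 4 is estimated at 10000 nM, within 2500 nM to 40000 nM.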

Compound 4, concentration for 50% growth inhibition: 10000 nM
Beside the measured number, compound 4's estimate shows no gap at the digits printed; low and high end bracket the measured number.
By their numbers in this assay, from the lowest: compounds 2, 3 and 4 (each within the scatter of the next). At a limit, above all of these: compound 1.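

At the double-bonded chain carbon bound to a double-bonded chain carbon, replacing 2-methoxyphenyl with 3,5-dichlorophenyl in this assay gives no change at the digits printed from compound 2 to compound 4 (within the scatter), so the hydrogen-bond acceptor of 2-methoxyphenyl, absent from 3,5-dichlorophenyl, makes no difference to the read-out in this pair. Going by these compounds alone, the gain over 4-(dimethylamino)phenyl is therefore not tied to 2-methoxyphenyl, since a second, quite different group gives an at least 10-fold lower number from compound 1 to compound 4 (1.00 log units; beyond the scatter), and at this place compound 1 is so far the only compound apart from the other two. Compound 1 stands at a limit: the limit of > 100000 nM in this assay, at which 1 of the 4 values shown sits.

Going by these compounds, it remains open whether the gap reflects something particular to 4-(dimethylamino)phenyl or whether other groups at this place would also separate from the level of compound 2, at 10000 nM; an unsubstituted phenyl would help to settle this. Also open is whether a carboxylic acid or a primary amine on the phenyl group at this place would move the read-out in either direction, as the three groups shown give no sign of what would take it past that level.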